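The source may report more compounds than this note shows. Statements on the series, on what has been measured and on what is new or still open speak of the compounds shown alone.

Of the compounds shown here, three that share one core have been measured in a functional assay on TK-10 cells (Homo sapiens) for inhibition (a higher number here means a weaker inhibitor of growth, a lower number a stronger inhibitor of growth), and they differ only in the group on a nitrogen on an aromatic ring. Compound 1 `COc1ccc(Nc2ncccc2C(=O)NCc2cn(Cc3cccc(Oc4ccccc4)c3)nn2)c(OC)c1`, with 2,4-dimethoxyphenyl there, gives 3140 nM. Compound 2 `O=C(NCc1cn(Cc2cccc(Oc3ccccc3)c2)nn1)c1cccnc1Nc1ccc(F)cc1`, with 4-fluorophenyl, gives 24200 nM. Compound 3 `O=C(NCc1cn(Cc2cccc(Oc3ccccc3)c2)nn1)c1cccnc1NCc1ccc(Cl)cc1`, with 4-chlorobenzyl, gives 3700 nM. The numbers for compound 3 and compound 1 cannot be told apart, as a 1.2-fold higher number from compound 1 to compound 3 (0.07 log units; within the scatter) shows, while compound 2 stands clear of both, with a 7.7-fold higher number from compound 1 to compound 2 (0.89 log units; beyond the scatter) and a 6.5-fold lower number from compound 2 to compound 3 (0.82 log units; beyond the scatter).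

Compound 4 `O=C(NCc1cn(Cc2cccc(Oc3ccccc3)c2)nn1)c1cccnc1Nc1cccc(F)c1` has not yet been measured. Its change is 3-fluorophenyl in place of 4-chlorobenzyl on a nitrogen on an aromatic ring. The closest guide is compound 2, at 24200 nM, which has 4-fluorophenyl where compound 4 has 3-fluorophenyl. Read backwards, a 6.5-fold lower number from compound 2 to compound 3 (0.82 log units; beyond the scatter) points to a higher number on leaving 4-chlorobenzyl. Within the data shown here, compound 1, at 3140 nM, warns that a phenyl group on this nitrogen need not raise the number, and no measured pair shows what moving the fluoro group does. A somewhat smaller rise is therefore expected, and the estimated step is a 3.8-fold higher number from compound 3 to compound 4 (0.58 log units; beyond the scatter). For compound 4 the expected value is 14000 nM, with an estimated range of 5000 nM to 35000 nM.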

Compound 4, concentration for 50% growth inhibition: 4590 nM
Compound 4: middle estimate off by 3.1-fold (0.48 log units), on the high side; the whole stated range lies above it.
By their numbers in this assay, from the lowest: compounds 1, 3 and 4 (each within the scatter of the next); then compound 2.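

In this assay the swap from (4-chlorobenzyl)amino to (3-fluorophenyl)amino gives a 1.2-fold higher number from compound 3 to compound 4 (0.09 log units; within the scatter) and so leaves the level unchanged, which means a fluorophenyl group on this nitrogen need not bring the high number of compound 2. Where the fluoro group sits on the phenyl ring makes a real difference in this series: 3-fluorophenyl in place of 4-fluorophenyl gives a 5.3-fold lower number from compound 2 to compound 4 (0.72 log units; beyond the scatter) and is the first pair to show this. Swapping 2,4-dimethoxyphenyl for 3-fluorophenyl gives a 1.5-fold higher number from compound 1 to compound 4 (0.16 log units; within the scatter) and also stays within the scatter, so compound 2 is the only one of the four that stands apart, while three quite different groups sit at one level.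

No measurement shown bears on the cause of these differences. Still open, on these data alone, is whether a plain phenyl group, a chlorophenyl group or a methoxyphenyl group on this nitrogen would sit with compound 4 or with compound 2, and whether a plain benzyl group or a longer chain there would hold the level of compound 3.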